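From 4-methylbenzyl to isopropyl on an amine nitrogen

The source may report more compounds than this note shows. Statements on the series, on what has been measured and on what is new or still open speak of the compounds shown alone.

- Compound 1 `COc1cc(Oc2cccc(Nc3ccccc3)c2)cc(OC)c1CNCc1ccc(F)cc1` gives 6770 nM on measurement
- Compound 2 `COc1cc(Oc2cccc(Nc3ccccc3)c2)cc(OC)c1CNCc1ccc(C)cc1` gives 11800 nM on measurement
- Compound 3 `COc1cc(Oc2cccc(Nc3ccccc3)c2)cc(OC)c1CNC(C)C` has no measurement yet

Both values come from a functional assay on SW-620 cells (Homo sapiens) for inhibition, read by MTT assay, with a stated time of 72 h (on this read-out higher numbers stand for weaker inhibition and lower numbers for stronger inhibition), and they stand close together. Within the data shown here, the one measured step is a 1.7-fold higher number from compound 1 to compound 2 (0.24 log units; within the scatter) and it comes with methyl in place of fluoro on an aromatic carbon. Compound 2 therefore stands level with compound 1 within the scatter.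

Compound 3 differs from compound 2 at another place, with isopropyl in place of 4-methylbenzyl on an amine nitrogen. Among the measured compounds shown here, no measured step covers this exchange, and the data hold no compound without the 4-methylbenzyl or a related benzyl group for comparison. The step from compound 1 to compound 2 only changed a group on the ring that now leaves, so it is a weak guide. Starting from compound 2 at 11800 nM in this assay and with that small step as the sole evidence, no clear move beyond the scatter is expected.

The expected change is a 1.2-fold higher number from compound 2 to compound 3 (0.07 log units; within the scatter) as a rough estimate. Compound 3 is estimated at 14000 nM with a wide expected range of 5000 nM to 40000 nM for the coming measurement.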

Compound 3, half-maximal inhibitory concentration: > 20000 nM
Compound 3 gave a limit, no number; the forecaster's own chance of this, stated with the estimate: 15%; at least 1.4-fold (0.15 log units) between middle value and limit.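

Compound 3 reads as a limit and not a number in this assay, the only such reading among these compounds: the limit of > 20000 nM in this assay, at which 1 of the 3 values shown sits. Exchanging the 4-fluorobenzyl group for isopropyl on the amine nitrogen gives an at least 2.9-fold higher number from compound 1 to compound 3 (0.47 log units; beyond the scatter), while exchanging the 4-methylbenzyl group for isopropyl gives an at least 1.6-fold higher number from compound 2 to compound 3 (0.22 log units; that floor lies within the scatter). Among these compounds, the earlier methyl in place of fluoro on an aromatic carbon had stayed within the scatter, so this is the first sign that the group on the amine nitrogen can move the number beyond it, and here the move runs toward weaker inhibition, at least against the 4-fluorobenzyl compound.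

As far as these compounds go, how far compound 3 lies past its limit stays open, and with it the full size of both steps. Also open, from the compounds shown here alone, is whether the aromatic ring that leaves or simply the size of the group matters, a question that an unsubstituted benzyl, a cyclohexylmethyl group or a longer chain such as n-butyl on this nitrogen would help to separate.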